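Straightening the Chain on the Ring Nitrogen

The source may hold more compounds than are shown below. What is called first, only, known or untested is meant among the compounds shown, and "the series" means these compounds.

Among the measured compounds shown here, compound 2 `COc1ccc(Cc2nn(C(C)(C)C)c(=O)c3ccccc23)cc1OC` in a functional assay on aorta with Alpha-1D adrenergic receptor (Rattus norvegicus) as the target (a higher number here means that more compound is needed for the effect, a lower number that less compound is needed), gives 10000 nM, the only value here that is a number. Compound 1 `COc1ccc(Cc2nn(-c3ccccc3)c(=O)c3ccccc23)cc1OC` reaches only a limit of the assay, > 100000 nM. For the measured compounds named here, the single measured step, an at least 10-fold lower number from compound 1 to compound 2 (1.00 log units; beyond the scatter), was large. Compound 3 `CCCCn1nc(Cc2ccc(OC)c(OC)c2)c2ccccc2c1=O` differs from compound 2 by butyl in place of tert-butyl on an aromatic nitrogen. Going by the values given here, no measured step swaps one alkyl group for another of equal size, so that earlier step offers little guidance, and the expected change is no change at the digits printed from compound 2 to compound 3 (within the scatter), nothing beyond the scatter. Compound 3 is therefore estimated at 10000 nM, lying between 3000 nM and 35000 nM.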

Compound 3, half-maximal effective concentration: 5400 nM
Estimate against measurement, compound 3: 1.9-fold (0.27 log units) above; low and high end bracket the measured number.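

Butyl and tert-butyl carry the same atoms joined differently, and in this assay this swap gives a 1.9-fold lower number from compound 2 to compound 3 (0.27 log units; within the scatter) with no change beyond the scatter, so branching of the chain on this nitrogen does not separate the two compounds. Butyl in place of phenyl gives an at least 18-fold lower number from compound 1 to compound 3 (1.26 log units; beyond the scatter) and thus repeats, with an unbranched chain, the large gap seen for tert-butyl. The size of that gap has no upper figure, since compound 1 stands at a limit and not at a number: the limit of > 100000 nM in this assay, at which 1 of the 3 values shown sits. As far as these compounds go, whether a methyl group, a longer chain or a chain ending in an amine would move the number at this nitrogen stays open.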